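The compounds below may be only part of what the source reports. "The series", "measured", "known", "first", "only" and "open" are said of these compounds alone.

In a functional assay on mitochondria from heart for inhibition of peroxisomal acyl-coenzyme A oxidase 1 (Rattus norvegicus) (on this read-out lower numbers stand for stronger inhibition and higher numbers for weaker inhibition), compound 1 `Cc1nc2cc(OC[C@H](O)CN3CCN(Cc4noc(-c5ccc(Cl)c(Cl)c5)n4)CC3)ccc2s1` gives 550 nM and compound 2 `Cc1nc2cc(OC[C@H](O)CN3CCN(Cc4noc(-c5ccc(Cl)cc5Cl)n4)CC3)ccc2s1` gives 130 nM. Within the data shown here, the only measured step, a 4.2-fold lower number from compound 1 to compound 2 (0.63 log units; beyond the scatter), changed the chlorine pattern on the phenyl ring and leaves compound 2 with the lower of the two numbers. Compound 3 `Cc1nc2cc(OC[C@H](O)CN3CCN(Cc4noc(-c5cccc(C#N)c5)n4)CC3)ccc2s1` differs from compound 2 by 3-cyanophenyl in place of 2,4-dichlorophenyl on an aromatic carbon. Among the measured compounds shown here, no measured step swaps both chlorines for a nitrile, so the earlier step offers little guidance, and a weakening of inhibition is the cautious expectation. The expected step is a 4.6-fold higher number from compound 2 to compound 3 (0.66 log units; beyond the scatter). Compound 3 is therefore estimated at 600 nM, within 150 nM to 2500 nM.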

Compound 3, half-maximal inhibitory concentration: 13400 nM
Estimate against measurement, compound 3: 22-fold (1.35 log units) below; measured number above the stated range.
By their numbers in this assay, from the lowest: compound 2; then compound 1; then compound 3.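

In this assay, the group on this carbon of the five-membered ring matters far more than the chlorine shift alone suggested. The step of a 100-fold higher number from compound 2 to compound 3 (2.01 log units; beyond the scatter) and the step of a 24-fold higher number from compound 1 to compound 3 (1.39 log units; beyond the scatter) show that 3-cyanophenyl gives much weaker inhibition than either dichlorophenyl group. Nothing available explains why this change weakens inhibition so strongly.

The compounds shown leave open whether the weakening goes with the incoming nitrile or with the loss of both chlorines. A plain phenyl or a 3-chlorophenyl group at this place would help separate those two readings.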